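A few compounds are considered here, and "the series" means these few. Any claim that something is new, unique, unknown or untested is made for them only; others in the source may bear on it.

Measured compounds:
compound 1, `Cc1cc2c(c(N)nn2C)c(N2CCCCC2)n1` — 7%
compound 2, `Cc1cc2c(cn1)c(N)nn2C` — -2%

Both compounds were tested in an assay on isolated protein for inhibition of MAP kinase-activated protein kinase 2 (Homo sapiens), read by mobility shift assay, tested at 30 uM; a higher number here means more inhibition at the concentration tested (going by the name of the read-out), a lower number less inhibition. Compound 1 gives 7% there, and compound 2 gives -2%. Going by the values given here, as written, the number for compound 2 is the smaller of the two, but the only step between them, a number 9 percentage points lower from compound 1 to compound 2 (within the scatter), is within the scatter, so the two compounds read as the same in this assay: neither shows inhibition that can be told apart from zero.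

Compound 3, `Cc1cc2[nH]nc(N)c2cn1`, has not yet been measured. It differs from compound 2 by hydrogen in place of methyl on an aromatic nitrogen. Among the compounds with values here, no measured step concerns this kind of change; the one step in hand, a number 9 percentage points lower from compound 1 to compound 2 (within the scatter), concerns a different place on the shared core and is itself within the scatter. There is therefore nothing here to suggest a step beyond the scatter, and the step of a number 2 percentage points higher from compound 2 to compound 3 (within the scatter) is expected to be no larger than that. On that basis compound 3 is estimated at 0%, within the range -12% to 12%.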

Compound 3, a percentage reported as inhibition, at one concentration (the size of the read-out at that concentration, not a potency): 7%
Compound 3: the middle estimate sits 7 percentage points below what was measured; measured number inside the range.
By their numbers in this assay, from the lowest: compounds 2, 1 and 3 (each within the scatter of the next).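

In this assay, hydrogen in place of methyl on the aromatic nitrogen of the five-membered ring gives a number 9 percentage points higher from compound 2 to compound 3 (within the scatter) and so cannot be told apart from the ordinary spread of repeated measurements. Going by these compounds alone, this is the first reading at this nitrogen, and it shows that taking away the methyl brings out no inhibition that stands clear of that spread at the single concentration tested, so this position joins the earlier piperidin-1-yl change as one with no readable effect so far. No outside data bear on why this swap reads as it does.

From the compounds shown here alone, whether a larger group on this aromatic nitrogen, such as an ethyl group or a benzyl group, would read any differently remains open. Going by these compounds, with all the readings this close together, it is also open whether the same swap of methyl for hydrogen would matter on a compound showing clear inhibition, such as one carrying a phenyl ring or a carboxylic acid in place of the amino group.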